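A few compounds are considered here, and "the series" means these few. Any claim that something is new, unique, unknown or untested is made for them only; others in the source may bear on it.

Three compounds have been measured in an assay on isolated protein for binding affinity to cysteinyl leukotriene receptor 1 (Cavia porcellus); a higher number here means a weaker inhibitor, a lower number a stronger inhibitor:

Compound 1 `c1cc(OCc2ccc3ccccc3n2)cc(-c2nn[nH]n2)c1`: 115 nM
Compound 2 `c1ccc2nc(COc3ccc(Cc4nnn[nH]4)cc3)ccc2c1`: 275 nM
Compound 3 `c1cc(OCCCCc2nnn[nH]2)cc(OCc2ccc3ccccc3n2)c1`: 75 nM

Compound 2 carries the highest number of the three in this assay. Its nearest neighbour is compound 1, whose number is lower by a margin beyond the usual scatter; compound 3 lies further away still, also beyond the scatter, and thus stands as the strongest binder of the set.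

Compound 4 `c1ccc2nc(COc3ccc(OCCCc4nnn[nH]4)cc3)ccc2c1` has not been measured. It differs from compound 2 in one place: 3-(1H-tetrazol-5-yl)propoxy in place of (1H-tetrazol-5-yl)methyl on an aromatic carbon. The substituent on the six-membered carbon ring becomes a longer, oxygen-linked chain ending in the same tetrazole.

Among the compounds with values here, no measured pair shows this exact step. Compound 3, however, carries an oxygen-linked tetrazole chain and gives 75 nM in this assay, the lowest number of the three, so a step downward in this assay of moderate size is expected from compound 2 to compound 4, a 2.8-fold lower number from compound 2 to compound 4 (0.44 log units; beyond the scatter), beyond the scatter. Compound 4 is therefore estimated at 100 nM, with a range from 40 nM to 300 nM.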

Compound 4, inhibition constant: 69 nM
Compound 4: middle estimate off by 1.4-fold (0.16 log units), on the high side; measured number inside the range.
By their numbers in this assay, from the lowest: compounds 4, 3 and 1 (each within the scatter of the next); then compound 2.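

In this assay, within the data shown here, this is the first direct reading of a single change on the six-membered carbon ring, para to a large group. Replacing (1H-tetrazol-5-yl)methyl with 3-(1H-tetrazol-5-yl)propoxy gives a clear gain (a 4.0-fold lower number from compound 2 to compound 4 (0.60 log units; beyond the scatter)), so this position tolerates a longer, oxygen-linked chain ending in the same tetrazole and the number improves with it. Nothing at hand explains the step.

The oxygen link and the added chain length change together here, so the compounds shown leave open which of them matters, and an all-carbon chain ending in the same tetrazole would separate the two. Also open, on these data alone, is whether a carboxylic acid in place of the tetrazole, or a longer chain, would keep this gain.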